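Cell Tolerance of Three Compounds and One Yet Unmeasured

The source may hold more compounds than are shown below. What is called first, only, known or untested is meant among the compounds shown, and "the series" means these compounds.

Measured compounds:
Compound 1, `COC(=O)C(=O)CNC1=CS(=O)(=O)O[C@@]12[C@@H](CO[Si](C)(C)C(C)(C)C)O[C@@H](n1cc(C)c(=O)n(C)c1=O)[C@@H]2O[Si](C)(C)C(C)(C)C`: 10300 nM
Compound 2, `Cc1cn([C@@H]2O[C@@H]3COC4(O)CS(=O)(=O)O[C@@]34[C@H]2O[Si](C)(C)C(C)(C)C)c(=O)[nH]c1=O`: 100000 nM
Compound 3, `Cc1cn([C@@H]2O[C@H](CO[Si](C)(C)C(C)(C)C)[C@@]3(OS(=O)(=O)C=C3NC(N)=O)[C@H]2O[Si](C)(C)C(C)(C)C)c(=O)n(C)c1=O`: 3700 nM

In a functional assay on MT4 cells (Homo sapiens) (a lower number here means that less compound is tolerated, a higher number that more compound is tolerated), compound 3 gives 3700 nM, the lowest of the three numbers recorded: compound 1 stands higher than it by a step beyond the scatter, and compound 2 lies furthest from it, also well beyond the scatter. For the measured compounds named here, only one measured step changes a single place, and it ends at compound 3: a 2.8-fold lower number from compound 1 to compound 3 (0.44 log units; beyond the scatter).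

Compound 4, `Cc1cn([C@@H]2O[C@H](CO[Si](C)(C)C(C)(C)C)[C@@]3(OS(=O)(=O)C=C3NCC(=O)C(N)=O)[C@H]2O[Si](C)(C)C(C)(C)C)c(=O)n(C)c1=O`, has not yet been measured. It differs from compound 3 in one place: (carbamoylcarbonyl)methyl in place of carbamoyl on an amine nitrogen. This change runs counter to the measured step, since it restores the (carbonyl)methyl chain that compound 1 carries on the same amine nitrogen, while the carbamoyl end is kept rather than the methoxycarbonyl end of compound 1. Going by the values given here, the step from compound 1 to compound 3 is the only guide, and it was of modest size. Compound 4 is therefore expected to move back toward the number of compound 1, a step of about a 2.2-fold higher number from compound 3 to compound 4 (0.33 log units; beyond the scatter), in the direction of a higher number. Compound 4 is estimated at 8000 nM, with a range from 3000 nM to 25000 nM.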

Compound 4, half-maximal cytotoxic concentration: 9590 nM
Compound 4: the middle estimate sits 1.2-fold (0.08 log units) below what was measured, and the stated range covers the measured number.
By their numbers in this assay, from the lowest: compound 3; then compounds 4 and 1 (each within the scatter of the next); then compound 2.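

In this assay, this amine nitrogen responds to the chain it carries more than to how that chain ends: with (carbamoylcarbonyl)methyl in place of carbamoyl, the result is a 2.6-fold higher number from compound 3 to compound 4 (0.41 log units; beyond the scatter), a modest step beyond the scatter that runs opposite to the earlier step between the two groups at this nitrogen. For the compounds shown here, the new compound also tests the end of the chain for the first time, and amino in place of methoxy on a carbonyl carbon gives a 1.1-fold lower number from compound 1 to compound 4 (0.03 log units; within the scatter), so the two cannot be ordered and this exchange shows no measurable change in cell tolerance. No supporting evidence is available to explain either step.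

Going by these compounds, what remains open is whether the carbonyl within the chain matters or only the chain's length, which a plain ethyl group or a longer alkyl chain on the same nitrogen could help to separate. It is also unclear how a charged end would read in this assay, since neither a carboxylic acid nor an amine at the end of the chain appears among these compounds.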